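Removing a methyl from an aromatic oxygen in compound 3

This account rests on a few compounds, and the source may have more. Where it says the series, first, only, none or still open, it means among the compounds named here.

Measured compounds:
compound 1 `COc1cc(C2Oc3cc(-c4oc5cc(O)cc(O)c5c(=O)c4O)ccc3OC2COC(=O)c2cc(O)c(O)c(O)c2)ccc1O` — 11900 nM
compound 2 `COc1cc(C2Oc3cc(-c4oc5cc(O)cc(O)c5c(=O)c4OC)ccc3OC2CO)ccc1O` — 11300 nM
compound 3 `COCC1Oc2ccc(-c3oc4cc(O)cc(O)c4c(=O)c3OC)cc2OC1c1ccc(O)c(OC)c1` — 10900 nM

In a functional assay on HUVEC cells (Homo sapiens) for inhibition, read by microscopy and crystal violet staining, with a stated time of 20 h (a higher number here means a weaker inhibitor, a lower number a stronger inhibitor), compound 3 gives the lowest of the three numbers, though its nearest neighbour compound 2 and its furthest neighbour compound 1 both lie within the scatter of it, so no order can be read among them. Within the data shown here, the one measured step, a 1.0-fold lower number from compound 2 to compound 3 (0.02 log units; within the scatter), concerns a methyl on an oxygen on a saturated carbon, a different place from the change now at hand. Compound 4 `COCC1Oc2ccc(-c3oc4cc(O)cc(O)c4c(=O)c3O)cc2OC1c1ccc(O)c(OC)c1` differs from compound 3 by hydrogen in place of methyl on an oxygen on an aromatic ring. Among the measured compounds shown here, no measured step bears on this change. Compound 4 is therefore expected to show a 1.0-fold higher number from compound 3 to compound 4 (0.00 log units; within the scatter), a step of no size beyond the scatter. The estimate for compound 4 is 11000 nM, with a range from 5000 nM to 24000 nM.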

Compound 4, half-maximal inhibitory concentration: 10500 nM
Beside the measured number, compound 4's estimate is 1.0-fold (0.02 log units) above it, within the range that was stated.
By their numbers in this assay, from the lowest: compounds 4, 3, 2 and 1 (each within the scatter of the next).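

Hydrogen in place of methyl on an oxygen on an aromatic ring gives a 1.0-fold lower number from compound 3 to compound 4 (0.02 log units; within the scatter) in this assay and so shows that methoxy and hydroxy cannot be told apart at this position. A second step, a 1.1-fold lower number from compound 1 to compound 4 (0.05 log units; within the scatter) on swapping (3,4,5-trihydroxyphenyl)carbonyl for methyl, shows the same for that much bigger change on an oxygen on a saturated carbon. No measurement here offers a reason for either result. From the compounds shown here alone, whether an ethyl group or a longer chain on the aromatic oxygen would shift the number stays open, as does the effect of an amine or a carboxylic acid there.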